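The source may report more compounds than this note shows. Statements on the series, on what has been measured and on what is new or still open speak of the compounds shown alone.

Measured in an ADME assay on MIA PaCa-2 cells (Homo sapiens) for cytotoxicity, read by MTT assay, with a stated time of 72 h; a higher number here means a weaker inhibitor, a lower number a stronger inhibitor:
- Compound 1 `C=CCOc1cc(C2=C(c3cc(OC)c(OC)c(OC)c3)C(=O)C(O)C2)ccc1OC`: > 100 ug/mL
- Compound 2 `COc1ccc(C2=C(c3cc(OC)c(OC)c(OC)c3)C(=O)C(O)C2)cc1`: < 1 ug/mL
- Compound 3 `COc1ccc(C2=C(c3cc(OC)c(OC)c(OC)c3)C(=O)C(O[SiH2]C(C)(C)C)C2)cc1OC(C)C`: > 100 ug/mL

All three values are limits, not numbers. Compound 3 stands at > 100 ug/mL, which is the limit of > 100 ug/mL in this assay, at which 2 of the 3 values shown sit.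

Compound 4 `COc1ccc(C2=C(c3cc(OC)c(OC)c(OC)c3)C(=O)C(O)C2)cc1OC(C)C` arises through one change: a hydrogen atom in place of a group of 5 heavy atoms (4 carbon, 1 silicon; no ring), on an oxygen on a saturated carbon. Among the compounds with values here, no measured step covers this exact change. Within the data shown here, the only step, an at least 100-fold lower number from compound 1 to compound 2 (2.00 log units; beyond the scatter), is large, but it replaces allyloxy on an aromatic carbon, and compound 4 keeps a group there. Compound 1 has that hydrogen on the oxygen and still gives > 100 ug/mL, again a limit. A modest move towards a lower number in this assay is therefore expected, with a real chance of no readable change. The expected change is an at least 2.0-fold lower number from compound 3 to compound 4 (0.30 log units; that floor lies within the scatter). For compound 4 the estimate is 50 ug/mL, with an expected range from 8 ug/mL to 150 ug/mL.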

Compound 4, half-maximal inhibitory concentration: > 100 ug/mL
Compound 4 gave a limit, no number (the forecaster's own chance of this, stated with the estimate: 50%); middle value at least 2.0-fold (0.30 log units) away from the limit.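

In this assay, isopropoxy in place of hydrogen on an aromatic carbon gives an at least 100-fold higher number from compound 2 to compound 4 (2.00 log units; beyond the scatter), so a large step at this place now holds for isopropoxy as well as allyloxy. Compound 4 has hydrogen in place of the group of 5 heavy atoms on the oxygen, yet it still gives > 100 ug/mL, which is a limit. Both ends of the steps from compound 3 and from compound 1 to compound 4 are limits, and neither step can be read.

Still open, on these data alone, is whether an amine or a fluorine on that aromatic carbon would give a readable number.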